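Changing the carbamate aryl group of compound 1

This account rests on a few compounds, and the source may have more. Where it says the series, first, only, none or still open, it means among the compounds named here.

Compound 1 `N#Cc1ccnc(OC(=O)N2CCC(C(c3ccccc3)c3ccccc3)CC2)c1` is a carbamate on a piperidine core. In an assay on isolated protein for inhibition of Fatty-acid amide hydrolase 1 (Rattus norvegicus), read by fluorescence (on this read-out lower numbers stand for stronger inhibition and higher numbers for weaker inhibition), compound 1 gives only a limit of the assay, > 1000 nM. Compound 3 `N#Cc1cccc(OC(=O)N2CCC(C(c3ccc(Cl)cc3)c3ccc(Cl)cc3)CC2)c1` likewise gives only a limit in this assay, > 1000 nM. For compound 2 `N#Cc1cccc(OC(=O)N2CCC(S(=O)(=O)C(c3ccccc3)c3ccccc3)CC2)c1` this assay reports "not determined" (no result reported), so no value is known. Two of the three entries sit at the same limit (the limit of > 1000 nM in this assay, at which 2 of the 3 values shown sit), and no single number anchors compound 1.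

Compound 4 `Cc1cc(C#N)cc(OC(=O)N2CCC(C(c3ccccc3)c3ccccc3)CC2)c1` differs from compound 1 by one change (3-cyano-5-methylphenyl in place of 4-cyanopyridin-2-yl on an oxygen next to a carbonyl group). Going by the values given here, as no measured pair shows a step, the expected step from compound 1 to compound 4 is estimated as a step that the limit leaves unreadable from compound 1 to compound 4, with a wide range. Compound 4 is expected to give about 1500 nM in this assay, between 200 nM and 10000 nM.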

Compound 4, half-maximal inhibitory concentration: > 1000 nM
Compound 4 gave a limit, no number (the forecaster's own chance of this, stated with the estimate: 55%); the middle value does not contradict the limit.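

No step can be read from compound 1 to compound 4, since both give only a limit in this assay: the limit of > 1000 nM in this assay, at which 3 of the 4 values shown sit.

The compounds shown leave open how strongly any of them inhibits, and whether changing the carbamate aryl group shifts inhibition at all.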